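Methyl in Place of Fluoro on a Shared Core

A few compounds are considered here, and "the series" means these few. Any claim that something is new, unique, unknown or untested is made for them only; others in the source may bear on it.

Of the compounds shown here, three that share one core have been measured in an assay on isolated protein for inhibition of proto-oncogene tyrosine-protein kinase receptor Ret variant V804M (Homo sapiens), read by 33P incorporation, with stated times of 15 min and 40 min; on this read-out higher numbers stand for weaker inhibition and lower numbers for stronger inhibition. Compound 1 `O=C(Nc1ccc(Br)cc1)Nc1ccc(Nc2ncnc3c2OCCN3)cc1` gives 2350 nM. Compound 2 `CC(C)(C)c1cc(NC(=O)Nc2ccc(Nc3ncnc4c3OCCN4)cc2)no1` gives 34 nM, and the step of a 69-fold lower number from compound 1 to compound 2 (1.84 log units; beyond the scatter) is the largest change seen in this set. Compound 3 `CC(C)(C)c1cc(NC(=O)Nc2ccc(Nc3ncnc4c3OCCN4)c(F)c2)no1` gives 22 nM, and the step of a 1.5-fold lower number from compound 2 to compound 3 (0.19 log units; within the scatter) is small. Compound 3 thus has the lowest number of the three, but its distance from compound 2 lies within the scatter, so the two cannot be ranked against each other.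

Compound 4 `Cc1cc(NC(=O)Nc2cc(C(C)(C)C)on2)ccc1Nc1ncnc2c1OCCN2` differs from compound 3 by methyl in place of fluoro on an aromatic carbon. Within the data shown here, no measured step swaps fluoro for methyl. Among the measured compounds shown here, the only step at that carbon is a 1.5-fold lower number from compound 2 to compound 3 (0.19 log units; within the scatter), which put fluoro in place of hydrogen and stayed within the scatter. Because a 1.5-fold lower number from compound 2 to compound 3 (0.19 log units; within the scatter) changed little, compound 4 is expected to show a step of roughly no change at the digits printed from compound 3 to compound 4 (within the scatter) in this assay. For compound 4 the estimate is 22 nM, with a range from 8 nM to 60 nM.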

Compound 4, half-maximal inhibitory concentration: 44 nM
For compound 4 the middle estimate is 2.0-fold (0.30 log units) below the measured one; low and high end bracket the measured number.
By their numbers in this assay, from the lowest: compounds 3, 2 and 4 (each within the scatter of the next); then compound 1.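

With methyl at this aromatic carbon, hydrogen, fluoro and methyl have now all been read at one place on the shared core. In this assay, both new steps, a 2.0-fold higher number from compound 3 to compound 4 (0.30 log units; within the scatter) and a 1.3-fold higher number from compound 2 to compound 4 (0.11 log units; within the scatter), stay within the scatter, so compound 2, compound 3 and compound 4 cannot be ranked, and this carbon has so far carried a carbon group as well as a halogen with no change that can be told from noise. No supporting measurement is available to say why these three numbers sit so close together.

As far as these compounds go, whether this holds for a methoxy group, an amine or a longer chain such as propyl at this carbon remains open. So does whether methyl would behave the same way with the 4-bromophenyl group of compound 1 in place of 5-(tert-butyl)-1,2-oxazol-3-yl.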